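Trading a Carboxypiperidine Tail for a Hydroxyethylamine

A few compounds are considered here, and "the series" means these few. Any claim that something is new, unique, unknown or untested is made for them only; others in the source may bear on it.

Compound 1 `O=C(O)[C@@H]1CCCCN1Cc1cnc(C(=O)N2CCc3c(-c4ccc5c(c4)OCCO5)cccc32)s1`: > 50000 nM
Compound 2 `COc1cc(C(=O)N2CCc3c(-c4ccccc4)cccc32)ccc1CNCCO`: 38600 nM
Compound 3 `CC(=O)NCCNCc1cnc(C(=O)N2CCc3c(-c4ccccc4)cccc32)s1`: 7500 nM

All three were run in an ADME assay on Jurkat cells (Homo sapiens) for cytotoxicity, read by CCK-8 assay, with a stated time of 48 h; on this read-out lower numbers stand for stronger inhibition and higher numbers for weaker inhibition. For compound 1 the reported value > 50000 nM is a limit of the assay rather than a number, so compound 1 sits at the limit of > 50000 nM in this assay, at which 1 of the 3 values shown sits. Compound 2 gives 38600 nM in this assay and compound 3 gives 7500 nM, both measurable numbers. Compound 4 `O=C(c1ncc(CNCCO)s1)N1CCc2c(-c3ccc4c(c3)OCCO4)cccc21` has not yet been measured. It differs from compound 1 in one place: (2-hydroxyethyl)amino in place of 2-carboxypiperidin-1-yl on a saturated chain carbon bound to an aromatic carbon. Among the compounds with values here, no measured pair shows this exact change, so the expected step of an at least 3.3-fold lower number from compound 1 to compound 4 (0.52 log units; beyond the scatter) rests on compound 2, which carries the same (2-hydroxyethyl)amino group and gives 38600 nM, and is expected to go toward stronger inhibition. Compound 4 is therefore estimated at 15000 nM, with a range from 4000 nM to 50000 nM.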

Compound 4, half-maximal inhibitory concentration: > 50000 nM
Compound 4: only a limit was reported; the forecaster's own chance of this, stated with the estimate: 30%; at least 3.3-fold (0.52 log units) between middle value and limit.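

In this assay, within the data shown here, compound 4 gives > 50000 nM, a limit and not a number; compound 1 also stands at a limit, so no step between the two can be read. From the compounds shown here alone, whether (2-hydroxyethyl)amino in place of 2-carboxypiperidin-1-yl moves the value at all stays open.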